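This account rests on a few compounds, and the source may have more. Where it says the series, first, only, none or still open, it means among the compounds named here.

Measured so far in a functional assay on PC-3 cells (Homo sapiens) for antiproliferative activity, read by MTT assay, with a stated time of 48 h; on this read-out lower numbers stand for stronger inhibition and higher numbers for weaker inhibition:
compound 1, `COc1ccc2nc(Nc3ccnc(Nc4ccc(S(N)(=O)=O)cc4)n3)sc2c1`, gives 3030 nM.
compound 2, `Cc1cnc(Nc2ccc(Cl)cc2)nc1Nc1nc2ccccc2s1`, returns only the limit of this assay, > 50000 nM.
compound 3, `NS(=O)(=O)c1ccc(Nc2nccc(Nc3nc4ccc(F)cc4s3)n2)cc1`, gives 920 nM.

Within the data shown here, the single step between compounds that differ in one place, a 3.3-fold lower number from compound 1 to compound 3 (0.52 log units; beyond the scatter), concerns fluoro in place of methoxy on the core of compound 1 and has no counterpart in the change now at hand. Compound 2 stands at the limit of > 50000 nM in this assay, at which 1 of the 3 values shown sits. Compound 4, `Cc1cnc(Nc2ccc([N+](=O)[O-])cc2)nc1Nc1nc2ccccc2s1`, differs from compound 2 as follows: nitro in place of chloro on an aromatic carbon. Among the measured compounds shown here, no measured step bears on nitro in place of chloro, so the expectation rests on compound 2 alone, with a large spread. Compound 4 is expected to stay near the limit, an expected step of an at least 1.1-fold lower number from compound 2 to compound 4 (0.04 log units; that floor lies within the scatter). Compound 4 is estimated at 45000 nM, in the range 12000 nM to 150000 nM.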

Compound 4, half-maximal inhibitory concentration: > 50000 nM
Compound 4 gave a limit, no number (the forecaster's own chance of this, stated with the estimate: 60%); middle value at least 1.1-fold (0.04 log units) away from the limit.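

Compound 2 and compound 4 both sit at a limit, so no step can be read between them: the limit of > 50000 nM in this assay, at which 2 of the 4 values shown sit.

Whether nitro in place of chloro changes the read-out at all remains open from the compounds shown.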